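This account rests on a few compounds, and the source may have more. Where it says the series, first, only, none or still open, it means among the compounds named here.

Measured in an ADME assay on THP-1 cells (Homo sapiens) for cytotoxicity, read by flow cytometry and propidium iodide staining, with a stated time of 72 h; on this read-out lower numbers stand for stronger inhibition and higher numbers for weaker inhibition:
compound 1 `COc1cccc(-c2oc3ccc(NC(C)=O)cc3c(=O)c2O)c1`: 50000 nM
compound 2 `CC(=O)Nc1ccc2oc(-c3cccc(C(F)(F)F)c3)c(O)c(=O)c2c1`: 1000 nM
compound 3 `Nc1ccc2oc(-c3cccc(C(F)(F)F)c3)c(O)c(=O)c2c1`: 2000 nM

Compound 2 sits at the low end of these numbers together with compound 3, the two lying within the scatter of each other, while compound 1 stands well apart. Compound 4 `COc1c(-c2cccc(C(F)(F)F)c2)oc2ccc(NC(C)=O)cc2c1=O` keeps all of compound 2 except for one change: methyl in place of hydrogen on an oxygen on an aromatic ring, or hydroxy to methoxy.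

Neither measured step touches that oxygen. The large one, a 50-fold lower number from compound 1 to compound 2 (1.70 log units; beyond the scatter), is a change on an aromatic carbon, and the other, a 2.0-fold higher number from compound 2 to compound 3 (0.30 log units; within the scatter), is a change on a nitrogen. They therefore give no direct guide to this change. For the measured compounds named here, they show only that one change in this small set can move the number a long way or leave it within the scatter. Going by the values given here, with so little to go on, a modest move towards a higher number in this assay is expected, but this direction is a judgement that no measured pair supports. The expected change is a 2.5-fold higher number from compound 2 to compound 4 (0.40 log units; beyond the scatter). Compound 4 is estimated at 2500 nM, with an expected range from 700 nM to 15000 nM.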

Compound 4, half-maximal inhibitory concentration: 52000 nM
Compound 4: the middle estimate sits 21-fold (1.32 log units) below what was measured; measured number outside the range, above it.
By their numbers in this assay, from the lowest: compounds 2 and 3 (each within the scatter of the next); then compounds 1 and 4 (each within the scatter of the next).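

For the compounds shown here, the first measured change on this oxygen in this assay is far from neutral: a 52-fold higher number from compound 2 to compound 4 (1.72 log units; beyond the scatter) is a large step, and hydroxy to methoxy alone accounts for it, since the acetyl on the nitrogen and the trifluoromethyl on the aromatic carbon stay as they are. Its size is close to that of a 50-fold lower number from compound 1 to compound 2 (1.70 log units; beyond the scatter) but runs towards a higher number, so this oxygen joins that aromatic carbon as a place where one small change moves the number well beyond the scatter, whereas the change on the nitrogen stayed within it. The data shown give no reason for the step, as nothing here bears on why adding this one methyl has so large an effect.

On these data alone, it remains open whether a longer chain such as ethyl on this oxygen, or an amine in place of the hydroxy, would give a number nearer that of compound 2 or that of compound 4. Also open, as far as these compounds go, is whether hydroxy to methoxy would give a step of similar size on compound 1 or compound 3, as this single pair cannot establish a wider pattern.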